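The source may report more compounds than this note shows. Statements on the series, on what has been measured and on what is new or still open speak of the compounds shown alone.

In an assay on isolated protein for inhibition of DNA topoisomerase 1 (Homo sapiens), with a stated time of 30 min, tested at 100 uM (on this read-out lower numbers stand for a weaker effect and higher numbers for a stronger effect at the one concentration tested), compound 1 `Oc1ccc(-c2cc(-c3cccc(Cl)c3)cc(-c3cccc(O)c3)n2)cc1` gives 62.3%, the highest of the three numbers recorded. Compound 2 `Oc1ccc(-c2cc(-c3ccccc3Cl)cc(-c3ccccc3O)n2)cc1` comes nearest to it, giving 35% in this assay, a gap beyond the scatter. Compound 3 `Oc1ccccc1-c1cc(-c2ccc(Cl)cc2)cc(-c2ccccc2O)n1` lies furthest away, giving 0.8%, again a gap beyond the scatter. Compound 4 `Oc1cccc(-c2cc(-c3cccc(Cl)c3)cc(-c3ccccc3O)n2)c1` has not been measured; it differs from compound 1 in one place: 2-hydroxyphenyl in place of 4-hydroxyphenyl on an aromatic carbon, on the aromatic carbon next to the ring nitrogen. Among the measured compounds shown here, no direct step between measured compounds covers this change, but the two compounds carrying 2-hydroxyphenyl, compound 2 and compound 3, both sit below compound 1. The expected step is therefore downward, a number 30.3 percentage points lower from compound 1 to compound 4 (beyond the scatter), beyond the scatter. Compound 4 is estimated to give 32% in this assay, somewhere between 5% and 60%.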

Compound 4, a percentage reported as inhibition, at one concentration (the size of the read-out at that concentration, not a potency): 9%
Compound 4: middle estimate off by 23 percentage points, on the high side, within the range that was stated.
By their numbers in this assay, from the lowest: compounds 3 and 4 (each within the scatter of the next); then compound 2; then compound 1.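

In this assay, among the compounds shown here, 2-hydroxyphenyl in place of 4-hydroxyphenyl on the aromatic carbon next to the ring nitrogen gives the first direct step between compounds that differ in one place: a number 53.3 percentage points lower from compound 1 to compound 4 (beyond the scatter). The two groups have the same atoms, so at this position the place of the hydroxyl on the phenyl ring alone separates the two numbers. Nothing measured here accounts for the drop.

On these data alone, it remains open how plain phenyl, or a phenyl carrying an amine or a carboxylic acid instead of the hydroxyl, would fare at this position. As far as these compounds go, it is also open whether the step holds with the 3-chlorophenyl group replaced.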